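Moving the Chlorine Around the Phenyl Ring

A few compounds are considered here, and "the series" means these few. Any claim that something is new, unique, unknown or untested is made for them only; others in the source may bear on it.

Within the data shown here, compound 3 `O=C(Nc1ccccc1O)C1CCc2ccccc2N1C(=O)c1ccccc1Cl` has the highest number of the three compounds measured so far in a functional assay on PC-3 cells (Homo sapiens) for cytotoxicity, read by sulforhodamine B assay, with a stated time of 72 h (on this read-out lower numbers stand for stronger inhibition of growth and higher numbers for weaker inhibition of growth), giving 60000 nM. Compound 1 `O=C(Nc1ccccc1O)C1CCc2ccccc2N1C(=O)c1ccccc1` gives 5690 nM and compound 2 `CCCCCCCCC(=O)N1c2ccccc2CCC1C(=O)Nc1ccccc1O` gives 45200 nM. The step of an 11-fold higher number from compound 1 to compound 3 (1.02 log units; beyond the scatter) shows that placing chlorine on an aromatic carbon raised the number a great deal, whereas a 7.9-fold higher number from compound 1 to compound 2 (0.90 log units; beyond the scatter) and a 1.3-fold higher number from compound 2 to compound 3 (0.12 log units; within the scatter) describe a different exchange of the whole group on the carbonyl carbon.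

Compound 4 `O=C(Nc1ccccc1O)C1CCc2ccccc2N1C(=O)c1cccc(Cl)c1` keeps every atom of compound 3 but joins them differently: 3-chlorophenyl in place of 2-chlorophenyl on a carbonyl carbon. Among the measured compounds shown here, no measured step tests this rearrangement directly. The nearest guidance is that compound 1, carrying no chlorine, gives 5690 nM, while the 2-chlorophenyl version sits far above it through an 11-fold higher number from compound 1 to compound 3 (1.02 log units; beyond the scatter). Moving the chlorine might recover part of that gap or none of it. A modestly lower number is therefore expected for compound 4, a 2.4-fold lower number from compound 3 to compound 4 (0.38 log units; beyond the scatter), with wide uncertainty. Compound 4 is estimated at 25000 nM, within 6000 nM to 90000 nM.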

Compound 4, concentration for 50% growth inhibition: 23300 nM
Beside the measured number, compound 4's estimate is 1.1-fold (0.03 log units) above it, within the range that was stated.
By their numbers in this assay, from the lowest: compound 1; then compounds 4, 2 and 3 (each within the scatter of the next, the first and the last beyond it).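

In this assay, among these compounds, the place of the chlorine on the ring matters by itself: with the same atoms, 3-chlorophenyl in place of 2-chlorophenyl gives a 2.6-fold lower number from compound 3 to compound 4 (0.41 log units; beyond the scatter), the first step here that changes only where a group sits. This recovers only part of the loss, since chloro in place of hydrogen still gives a 4.1-fold higher number from compound 1 to compound 4 (0.61 log units; beyond the scatter), so both chlorinated compounds stand above compound 1 with its unsubstituted phenyl. Set against the octyl group, 3-chlorophenyl gives a 1.9-fold lower number from compound 2 to compound 4 (0.29 log units; within the scatter), so these two groups on the carbonyl carbon cannot be told apart.

Still open, as far as these compounds go, is whether a fluoro or an amino group in place of the chloro group would match or improve on compound 1. Nothing measured here offers a reason for these differences.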